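The source may hold more compounds than are shown below. What is called first, only, known or untested is meant among the compounds shown, and "the series" means these compounds.

Working notes on the oxazole series. Compound 3 `O=C(O)COc1cccc(CC(C(=O)O)c2nc(-c3ccccc3)c(-c3ccccc3)o2)c1` is the reference point for the next step. In a functional assay for inhibition, with Homo sapiens as the target (on this read-out lower numbers stand for stronger inhibition and higher numbers for weaker inhibition), compound 3 gives 14000 nM, the highest of the two numbers in hand. The nearest measured neighbour is compound 2 `CCOC(=O)C(Cc1cccc(OCC(=O)O)c1OC)c1nc(-c2ccccc2)c(-c2ccccc2)o1`, which in this assay gives 1180 nM, a lower number by a margin that is beyond the scatter of repeats. Compound 1 `CCOC(=O)/C(=C\c1cccc(OCC(=O)OC(C)(C)C)c1)c1nc(-c2ccccc2)c(-c2ccccc2)o1` stands apart: in this assay compound 1 is reported only as a limit, > 60000 nM, and not as a number. Of the three results, one sits at the limit of > 60000 nM in this assay, at which 1 of the 3 values shown sits.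

Compound 4 `C=CCC(Cc1cccc(OCC(=O)O)c1)c1nc(-c2ccccc2)c(-c2ccccc2)o1` has not yet been run in this assay. It differs from compound 3 in a single place: allyl in place of carboxy on a saturated chain carbon bound to an aromatic carbon and a saturated chain carbon. Among the compounds with values here, no pair of measured compounds differs in exactly one place, so no measured step calibrates this exchange. Compound 2 carries a neutral group rather than carboxy on that chain carbon and shows the lower of the two numbers, though compound 2 also differs from compound 3 elsewhere. On that slim basis, a downward step is expected for compound 4, of a size that should exceed the scatter, written as a 4.0-fold lower number from compound 3 to compound 4 (0.60 log units; beyond the scatter). Compound 4 is therefore estimated at 3500 nM in this assay, with a plausible range from 800 nM to 16000 nM.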

Compound 4, half-maximal inhibitory concentration: 570 nM
The estimate for compound 4 lay 6.1-fold (0.79 log units) above the measured number; measured number below the stated range.
By their numbers in this assay, from the lowest: compound 4; then compound 2; then compound 3. At a limit, above all of these: compound 1.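

This position now has its first calibrated exchange: in this assay, replacing carboxy with allyl on a saturated chain carbon bound to an aromatic carbon and a saturated chain carbon gives a 25-fold lower number from compound 3 to compound 4 (1.39 log units; beyond the scatter) with everything else in the structure held the same. The position therefore accepts a group of the same heavy-atom count that has only carbon atoms and no hydrogen-bond donor or acceptor, and carboxy at this place is not needed for the lower number in this pair. The data shown give no measured property that would account for the size of this step.

With a single exchange at this place, the loss of carboxy cannot be separated from the gain of allyl, so a saturated propyl chain or a primary amide on the same carbon would be the informative comparison with both compound 3 and compound 4. Within the data shown here, it also remains open whether the step carries over to other members, since no second pair differs in this place alone, and whether a longer chain at this position would lower the number further.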